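This account rests on a few compounds, and the source may have more. Where it says the series, first, only, none or still open, it means among the compounds named here.

The compounds measured in a functional assay on HFL1 cells for antagonist activity at sphingosine 1-phosphate receptor 2 (Homo sapiens), read by ELISA, with a stated time of 24 h (on this read-out lower numbers stand for stronger inhibition and higher numbers for weaker inhibition), are:

compound 1 `CC(C(=O)O)c1nn(Cc2cn3cc(OCC4CC4)c(Cl)cc3n2)c2ccccc2c1=O`; compound 1 gives 1.3 nM
compound 2 `O=C(O)Cn1nc(Cn2cc3cc(OCC4CC4)c(Cl)cc3n2)c2ccccc2c1=O`; compound 2 gives 8.1 nM
compound 3 `O=C(O)Cc1nn(Cc2cn3cc(OCC4CC4)c(Cl)cc3n2)c2ccccc2c1=O`; compound 3 gives 4.8 nM

Compound 2 and compound 3 are built from the same atoms joined differently; the difference between the two cores is not broken down here, and in this assay their two values lie within the usual scatter of each other. From compound 3 to compound 1 the change is methyl in place of hydrogen on a saturated chain carbon bound to an aromatic carbon and a carbonyl carbon, and it produced a 3.7-fold lower number from compound 3 to compound 1 (0.57 log units; beyond the scatter).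

Compound 4 `C[C@H](C(=O)O)n1nc(Cn2cc3cc(OCC4CC4)c(Cl)cc3n2)c2ccccc2c1=O` carries the same kind of change on the core of compound 2: methyl in place of hydrogen on a saturated chain carbon bound to an aromatic nitrogen and a carbonyl carbon. The surroundings differ in one respect: in compound 4 the saturated chain carbon is bound to an aromatic nitrogen and a carbonyl carbon, whereas in compound 1 it is bound to an aromatic carbon and a carbonyl carbon. Among the measured compounds shown here, because a 3.7-fold lower number from compound 3 to compound 1 (0.57 log units; beyond the scatter) is the only precedent, and on a different core, the expectation for compound 4 is held loosely: a step of about a 2.7-fold lower number from compound 2 to compound 4 (0.43 log units; beyond the scatter) from compound 2 is expected in this assay. Compound 4 is accordingly estimated at 3 nM, within a range from 1.2 nM to 8 nM.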

Compound 4, half-maximal inhibitory concentration in the sphingosine 1-phosphate receptor 2 assay: 3.5 nM
Beside the measured number, compound 4's estimate is 1.2-fold (0.07 log units) below it, within the range that was stated.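

In the sphingosine 1-phosphate receptor 2 assay, methyl in place of hydrogen on the core of compound 2 gave a 2.3-fold lower number from compound 2 to compound 4 (0.36 log units; beyond the scatter), and the step on this core agrees with the one on the other core, with no difference beyond the scatter: the same change on two cores in the sphingosine 1-phosphate receptor 2 assay, a 3.7-fold lower number (0.57 log units; beyond the scatter) from compound 3 to compound 1 and a 2.3-fold lower number (0.36 log units; beyond the scatter) from compound 2 to compound 4, 1.6-fold (0.20 log units) apart, within the scatter of two such steps In a physicochemical assay for solubility, measured as thermodynamic solubility, at pH 7.4 (on this read-out higher numbers stand for higher solubility and lower numbers for lower solubility), compound 2 gives 334 ug/mL and compound 4 gives 958 ug/mL and the same change on the core of compound 2 came with higher solubility: the measured solubility of compound 2, 334 ug/mL, and of compound 4, 958 ug/mL, a 2.9-fold higher number (0.46 log units; beyond the scatter) This shows agreement between two pairs on two related cores only, not a rule for other cores, and the solubility step rests on a single pair, so it says nothing about whether that gain carries over to the core of compound 1.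

The compounds shown leave open whether an ethyl group on that saturated chain carbon would give a step of similar size, and how the mirror-image form of the 1-carboxyethyl group in compound 4 would compare. They also leave open whether a primary amide or a tetrazole could stand in place of the carboxylic acid.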